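A few compounds are considered here, and "the series" means these few. Any claim that something is new, unique, unknown or untested is made for them only; others in the source may bear on it.

In an ADME assay on HEK-293T cells (Homo sapiens) for inhibition, read by CCK-8 assay, with a stated time of 48 h, tested at 20 uM (on this read-out lower numbers stand for less inhibition of growth and higher numbers for more inhibition of growth at the one concentration tested), compound 1 `Cc1ccc(S(=O)(=O)Oc2ccccc2/C=C(\C#N)C(=O)Nc2nnc(Cc3cccc4ccccc34)s2)cc1` gives 23%, compound 2 `N#C/C(=C\c1ccccc1OS(=O)(=O)c1ccc(Cl)cc1)C(=O)Nc1nnc(Cc2cccc3ccccc23)s1` gives 16% and compound 3 `N#C/C(=C\c1ccccc1OS(=O)(=O)c1ccc(F)cc1)C(=O)Nc1nnc(Cc2cccc3ccccc23)s1` gives 15%, so compound 1 stands within the scatter of both others. Compound 4 `Cc1ccc(Cc2nnc(NC(=O)/C(C#N)=C/c3ccccc3OS(=O)(=O)c3ccc(C)cc3)s2)cc1` has not yet been measured. It carries 4-methylphenyl in place of naphthalen-1-yl on a saturated chain carbon bound to an aromatic carbon. The measured steps, a number 7 percentage points lower from compound 1 to compound 2 (within the scatter), a number 8 percentage points lower from compound 1 to compound 3 (within the scatter) and a number 1 percentage points lower from compound 2 to compound 3 (within the scatter), all lie within the scatter, but each exchanges methyl, chloro or fluoro on an aromatic carbon, and none touches the naphthalen-1-yl. They bear on this change only indirectly, and no step beyond the scatter is expected. The estimated step is a number 3 percentage points lower from compound 1 to compound 4 (within the scatter). Compound 4 is expected at 20%, with an estimated range of 6% to 36%.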

Compound 4, percent growth inhibition at one concentration: 22%
Compound 4: middle estimate off by 2 percentage points, on the low side, and the stated range covers the measured number.
By their numbers in this assay, from the lowest: compounds 3, 2, 4 and 1 (each within the scatter of the next).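

This is the only step shown that alters the group on a saturated chain carbon bound to an aromatic carbon: in this assay, 4-methylphenyl in place of naphthalen-1-yl gives a number 1 percentage points lower from compound 1 to compound 4 (within the scatter). Going from two six-membered aromatic rings to one at this place therefore leaves the read-out within the scatter. No measurement here offers an explanation for this result. Still open, on these data alone, is whether an amine or a carboxylic acid at this place would move the number beyond the scatter. Also open, as far as these compounds go, is whether chloro or fluoro in place of methyl would give similar steps alongside 4-methylphenyl.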